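The source may hold more compounds than are shown below. What is called first, only, known or untested is meant among the compounds shown, and "the series" means these compounds.

Compound 1 `CCOC(=O)N1CCC(N(Cc2cc(Cl)ccc2O)C(=O)N(C)C)CC1` and compound 2 `CCOC(=O)N1CCC(N(Cc2ccc(O)cc2)C(=O)N(C)C)CC1` share the same core and differ only in the ring hung from it. In a functional assay on K562 cells (Homo sapiens) for antiproliferative activity, read by MTT assay, with a stated time of 48 h (on this read-out higher numbers stand for weaker inhibition and lower numbers for stronger inhibition), compound 1 gives 38400 nM, and compound 2 gives 41800 nM. Compound 3 `CN(C)C(=O)N(Cc1ccc([N+](=O)[O-])cc1)Cc1ccco1`, built on a different skeleton, gives 35400 nM in this assay. Compound 2 has the highest of the three numbers, but its gaps to compound 1 and to compound 3 both lie within the scatter, so the three compounds cannot be told apart on these readings. Within the data shown here, the only single-point step measured so far, a 1.1-fold higher number from compound 1 to compound 2 (0.04 log units; within the scatter), shows that exchanging the two rings barely moves the number.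

Compound 4 `CCOC(=O)N1CCC(N(Cc2cc(Br)ccc2O)C(=O)N(C)C)CC1` has not yet been measured. Its change from compound 2 is 5-bromo-2-hydroxyphenyl in place of 4-hydroxyphenyl on a saturated chain carbon bound to an amide-type nitrogen. Among the measured compounds shown here, the incoming ring is the one compound 1 carries, with bromine standing where compound 1 has chlorine. Because a 1.1-fold higher number from compound 1 to compound 2 (0.04 log units; within the scatter) stayed within the scatter, returning to a ring of this kind is expected to bring no step beyond the scatter in this assay, which corresponds to an expected step of a 1.1-fold lower number from compound 2 to compound 4 (0.05 log units; within the scatter). Compound 4 is therefore estimated at 37000 nM, with a range from 16000 nM to 85000 nM.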

Compound 4, half-maximal inhibitory concentration: 41800 nM
Compound 4: middle estimate off by 1.1-fold (0.05 log units), on the low side, within the range that was stated.
By their numbers in this assay, from the lowest: compounds 3, 1, 2 and 4 (each within the scatter of the next).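

In this assay, the exchange of 4-hydroxyphenyl for 5-bromo-2-hydroxyphenyl gives no change at the digits printed from compound 2 to compound 4 (within the scatter), so this second ring change on the shared core also leaves the reading within the scatter. The halogen itself is now tested too: bromo in place of chloro on an aromatic carbon gives a 1.1-fold higher number from compound 1 to compound 4 (0.04 log units; within the scatter), also within the scatter, so compounds 1, 2 and 4 cannot be told apart, whether the ring carries chlorine, bromine or no halogen. None of the information available explains why these ring changes leave the reading so flat.

Going by these compounds, all three of these rings carry a hydroxyl group, so it remains open whether a plain phenyl ring, or a ring bearing an amine or a carboxylic acid, would move the number beyond the scatter at this place. On these data alone, it also remains open whether changes elsewhere on the shared core would matter more, and compound 3 cannot settle this, as it differs from these compounds in more than one place.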